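Vero cytotoxicity notes: carbamate capping of compound 1

The source may report more compounds than this note shows. Statements on the series, on what has been measured and on what is new or still open speak of the compounds shown alone.

Compound 1 `N#Cc1cc([N+](=O)[O-])ccc1Nc1ccc(OC2CCNCC2)cc1` in an ADME assay on Vero cells (Chlorocebus sabaeus) for cytotoxicity, read by fluorescence and resazurin assay, with a stated time of 72 h (on this read-out higher numbers stand for weaker inhibition and lower numbers for stronger inhibition), gives > 100000 nM, which is a limit of the assay and not a number.
Compound 2 `COc1ccc(CNC(=O)c2nc3cc(C(F)(F)F)cc([N+](=O)[O-])c3s2)cc1` in this assay gives > 100000 nM, likewise a limit.
Compound 3 `O=C(NCc1ccc(N2CCC(c3ccc(OC(F)(F)F)cc3)CC2)cc1)c1nc2cc(C(F)(F)F)cc([N+](=O)[O-])c2s1` in this assay gives > 100000 nM, also a limit.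

Compound 1 stands where every value in the set stands: the limit of > 100000 nM in this assay, at which 3 of the 3 values shown sit. Among the compounds with values here, no two of the measured compounds differ in a single place, so no measured step is available, and the three values say only that none of the compounds reached half-maximal inhibition within the tested range.

Compound 4 `CC(C)(C)OC(=O)N1CCC(Oc2ccc(Nc3ccc([N+](=O)[O-])cc3C#N)cc2)CC1` is the unmeasured partner of compound 1. The change from compound 1 to compound 4 is tert-butoxycarbonyl in place of hydrogen on an amine nitrogen in a ring. With all three measured values sitting at the limit, no direction can be read from the set, and the expected step in this assay is none beyond the scatter. The step that the limit leaves unreadable from compound 1 to compound 4 is therefore expected to lie within the scatter. For compound 4 the value expected in this assay is 150000 nM, in a range from 60000 nM to 400000 nM, with a strong chance that the assay again reports only a limit.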

Compound 4, half-maximal inhibitory concentration: > 100000 nM
Compound 4 ended at the assay's limit; the forecaster's own chance of this, stated with the estimate: 85%; the middle value does not contradict the limit.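

Compound 1 and compound 4 both stand at a limit of the assay and not at a number, and the step between them cannot be read. The compounds shown leave open whether tert-butoxycarbonyl in place of hydrogen on the ring amine nitrogen changes cytotoxicity at all, and at what concentration any of them would reach half-maximal inhibition.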